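The source may hold more compounds than are shown below. What is called first, only, known or untested is meant among the compounds shown, and "the series" means these compounds.

Of the compounds shown here, three built on one shared core have so far been tested in an ADME assay on L02 cells (Homo sapiens) for antiproliferative activity, read by MTT assay, with a stated time of 48 h; a lower number here means a stronger inhibitor, a higher number a weaker inhibitor. Compound 1 `N#CC1=C(N)Oc2c(c3nc4ccccc4nc3c3ccccc23)C12C(=O)N(Cc1cnnn1-c1ccc(Cl)cc1)c1ccccc12` carries a 4-chlorophenyl group on an aromatic nitrogen. In this assay compound 1 reaches only the limit of > 50000 nM. Compound 2 `N#CC1=C(N)Oc2c(c3nc4ccccc4nc3c3ccccc23)C12C(=O)N(Cc1cnnn1-c1cc(Cl)ccc1Cl)c1ccccc12` carries a 2,5-dichlorophenyl group in that place. In this assay compound 2 likewise returns the limit of > 50000 nM. The step that the two limits leave unreadable from compound 1 to compound 2 cannot be read, since both ends are limits. Compound 3 `Cc1ccccc1-n1nncc1CN1C(=O)C2(C(C#N)=C(N)Oc3c(N)cc4nc5ccccc5nc4c32)c2ccccc21` has a differently substituted core and bears a 2-methylphenyl group on the aromatic nitrogen. In this assay compound 3 also gives the limit of > 50000 nM. Compound 3 thus stands at the limit of > 50000 nM in this assay, at which 3 of the 3 values shown sit, with no numeric value that would place it relative to the other two.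

Compound 4 `CCc1cccc(CC)c1-n1nncc1CN1C(=O)C2(C(C#N)=C(N)Oc3c(N)cc4nc5ccccc5nc4c32)c2ccccc21` follows from compound 3 by the change (2,6-diethylphenyl in place of 2-methylphenyl on an aromatic nitrogen). Among the compounds with values here, the single measured step is unreadable and so gives no guidance on the size or direction of this change. Within the data shown here, because all values so far rest at the limit of > 50000 nM in this assay, at which 3 of the 3 values shown sit, compound 4 is expected to remain at that limit too, with an estimated value of 80000 nM and a range from 30000 nM to 300000 nM. The expected step is accordingly a step that the limit leaves unreadable from compound 3 to compound 4, which is taken to mean no change beyond the scatter.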

Compound 4, half-maximal inhibitory concentration: > 50000 nM
Compound 4 was reported as a limit; the forecaster's own chance of this, stated with the estimate: 85%; the middle value is on the limit's open side.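

In this assay compound 4 is reported only as a limit, > 50000 nM. Compound 3 is also reported only as a limit, so the step to compound 4 cannot be read. The compounds shown leave open whether the group on the aromatic nitrogen affects the half-maximal inhibitory concentration at all, because every result rests at one point: the limit of > 50000 nM in this assay, at which 4 of the 4 values shown sit.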